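Methoxyphenyl isomer swap on the ring amine nitrogen

A few compounds are considered here, and "the series" means these few. Any claim that something is new, unique, unknown or untested is made for them only; others in the source may bear on it.

Of the compounds shown here, two have numbers so far. Compound 1 `O/N=C(\CCN1CCN(c2ccccn2)CC1)c1ccc(Cl)cc1` gives 475 nM in a functional assay on HEK293 cells with D(4) dopamine receptor (Homo sapiens) as the target, read by FLIPR; on this read-out higher numbers stand for an effect only at larger amounts of compound and lower numbers for an effect already at smaller amounts. Compound 2 `CCO/N=C(\CCN1CCN(c2ccccc2OC)CC1)c1ccccc1` gives 338 nM in this assay. Compound 2 has the lower of the two numbers, but its gap to compound 1 lies within the scatter, so the two cannot be ordered on these data.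

Compound 3 `CCO/N=C(\CCN1CCN(c2ccc(OC)cc2)CC1)c1ccccc1` is the next candidate. It differs from compound 2 in one place: 4-methoxyphenyl in place of 2-methoxyphenyl on an amine nitrogen in a ring. Among the compounds with values here, no pair of measured compounds differs by this change, so there is no measured step to lean on; the only guide is that compound 1 and compound 2, which differ at several places at once, sit within the scatter of each other in this assay.

The step of a 1.2-fold higher number from compound 2 to compound 3 (0.07 log units; within the scatter) is estimated to fall within the scatter, in neither direction, with wide uncertainty given the lack of a comparable step. Compound 3 is expected to give 400 nM in this assay, with a range from 100 nM to 1600 nM.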

Compound 3, half-maximal effective concentration: > 10000 nM
Compound 3 ended at the assay's limit (the forecaster's own chance of this, stated with the estimate: 5%); at least 25-fold (1.39 log units) between middle value and limit.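

Within the data shown here, this is the first comparison of compounds that differ in one place, and it shows that the group on the amine nitrogen in the ring strongly shapes the result in this assay. Moving from 2-methoxyphenyl to 4-methoxyphenyl gives an at least 29-fold higher number from compound 2 to compound 3 (1.47 log units; beyond the scatter). The entering and leaving groups match in heavy atoms, hydrogen-bond donors, hydrogen-bond acceptors and charge, so these counts do not separate the two compounds; only the way the atoms are joined does.

Compound 3 stands at a limit of the assay and not at a number, so the full size of the step stays unknown: the limit of > 10000 nM in this assay, at which 1 of the 3 values shown sits.

The compounds shown leave open whether a plain phenyl group at this place would stay close to compound 2 or fall to the level of compound 3, and whether an ethoxy group in place of the methoxy on the 2-methoxyphenyl ring would be accepted. They also leave open whether the same swap has a comparable effect on the core of compound 1.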